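Swapping a vinyl for an ethynyl on the piperazine chain

The source may report more compounds than this note shows. Statements on the series, on what has been measured and on what is new or still open speak of the compounds shown alone.

Measured so far in a functional assay on ileum for antagonist activity at muscarinic acetylcholine receptor M3 (Cavia porcellus); on this read-out lower numbers stand for stronger inhibition and higher numbers for weaker inhibition:
compound 1 `COc1ccccc1N1CCN(CC(=O)C(O)(c2ccccc2)C2CCC2)CC1` gives > 10000 nM
compound 2 `C=CCN1CCN(CC(=O)C(O)(c2ccccc2)C2CCCCC2)CC1` gives 25.6 nM
compound 3 `O=C(CN1CCN(Cc2cccs2)CC1)C(O)(c1ccccc1)C1CCC1` gives 43.8 nM

The three compounds share one core and differ only in the group attached to the amine nitrogen in the ring. Compound 1 gives only a limit in this assay, not a number; its value sits at the limit of > 10000 nM in this assay, at which 1 of the 3 values shown sits. Compound 2 and compound 3 both give plain numbers, and these two numbers lie within the usual scatter of each other, so neither can be called stronger. For the measured compounds named here, the one measured step, an at least 220-fold lower number from compound 1 to compound 3 (2.35 log units; beyond the scatter), shows how much this position can matter when a whole aryl group is exchanged for a different ring attached through a chain.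

Compound 4 `C#CCN1CCN(CC(=O)C(O)(c2ccccc2)C2CCCCC2)CC1` is the next candidate. It differs from compound 2 only by ethynyl in place of vinyl on a saturated chain carbon bound to an amine nitrogen in a ring. Going by the values given here, this is a far smaller change than the one from compound 1 to compound 3: the chain length stays the same, no ring is added or lost, and no donor or acceptor changes. Among the compounds with values here, no measured step here tracks such a small alteration, so there is no direct guide, and the expectation is a step of no more than the scatter. This means an expected 1.2-fold higher number from compound 2 to compound 4 (0.07 log units; within the scatter). For compound 4 the estimated value is 30 nM, with a likely range from 10 nM to 100 nM.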

Compound 4, antagonist equilibrium constant: 260 nM
Beside the measured number, compound 4's estimate is 8.7-fold (0.94 log units) below it, and the stated range ends below it.
By their numbers in this assay, from the lowest: compounds 2 and 3 (each within the scatter of the next); then compound 4. At a limit, above all of these: compound 1.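

In this assay, the group on the amine nitrogen in the ring turns out to be sensitive to more than the exchange of a whole ring: turning a double bond into a triple bond gives a 10-fold higher number from compound 2 to compound 4 (1.01 log units; beyond the scatter). Allyl to propargyl is therefore not an interchangeable swap here, even though no ring is gained or lost and no hydrogen-bond donor or acceptor enters. Nothing in the data shown accounts for the size of this step.

For the compounds shown here, only one pair carries this change, so whether it behaves the same way on a different core stays open. Also open, as far as these compounds go, is where a saturated propyl group, with neither a double nor a triple bond, or a longer chain such as butyl would fall.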